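Replacing a pyrazolyl amide substituent with sec-butyl

The source may report more compounds than this note shows. Statements on the series, on what has been measured and on what is new or still open speak of the compounds shown alone.

The series is built around an amide nitrogen that carries a thiophen-2-ylmethyl group throughout. Compound 1 `CCN(Cc1cccs1)C(=O)COc1ccc(C(=O)O)cc1` gives "not active" (no number reported) in an assay on HEK293 cells for agonist activity at transient receptor potential cation channel subfamily M member 8 (Homo sapiens), read by fluorescence and calcium flux, with a stated time of 15 min (on this read-out higher numbers stand for an effect only at larger amounts of compound and lower numbers for an effect already at smaller amounts), and compound 3 `CCN(Cc1cccs1)C(=O)c1cc2cc(C)ccc2n1C` gives "not active" (no number reported) in this assay. For the measured compounds named here, compound 2 `Cc1ccc(OCC(=O)N(Cc2cccs2)c2ccn(C)n2)cc1` is the only member of the set with a numerical result, giving 855 nM in this assay; it therefore stands alone, with no measured neighbour to set a step against.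

Compound 4 `CCC(C)N(Cc1cccs1)C(=O)COc1ccc(C)cc1` differs from compound 2 in one place: sec-butyl in place of 1-methyl-1H-pyrazol-3-yl on an amide-type nitrogen. Going by the values given here, no measured pair shows what such an exchange on the amide nitrogen does in this assay, and the two inactive compounds differ from compound 2 in more than this one position, so they do not fix a direction. He expects that compound 4 will give a weaker result than compound 2, with a step of a 2.9-fold higher number from compound 2 to compound 4 (0.47 log units; beyond the scatter) that lies beyond the usual scatter, since the one active compound carries the aromatic substituent that compound 4 lacks. His estimate for compound 4 in this assay is 2500 nM, within a range from 600 nM to 10000 nM.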

Compound 4, half-maximal effective concentration: 2000 nM
Compound 4: the middle estimate sits 1.3-fold (0.10 log units) above what was measured, within the range that was stated.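

For the compounds shown here, the exchange gives the first measured step at this position, on an amide-type nitrogen: a 2.3-fold higher number from compound 2 to compound 4 (0.37 log units; beyond the scatter) in this assay. Compound 4 still gives 2000 nM with sec-butyl, which has no ring and no hydrogen-bond acceptors, so the 1-methyl-1H-pyrazol-3-yl group is not needed for a numerical result, although the number is higher without it. Nothing measured here accounts for the step.

Going by these compounds, whether a phenyl ring, a cyclopentyl ring or a chain carrying an amine on this nitrogen would raise or lower the number remains open. The effect of ethyl at this position is also unsettled, as the two compounds that carry it differ from compound 4 in other places as well.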